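The source may hold more compounds than are shown below. What is called first, only, known or untested is meant among the compounds shown, and "the series" means these compounds.

Measured compounds:
Compound 1 `Oc1ccc(CN[C@@H]2CO[C@H](C(c3ccc(F)cc3)c3ccc(F)cc3)C[C@H]2O)cc1F` in an assay on striatum for inhibition of sodium-dependent dopamine transporter (Rattus norvegicus) (a higher number here means a weaker inhibitor, a lower number a stronger inhibitor), gives 13.1 nM.
Compound 2 `COc1ccc(CN[C@@H]2CO[C@H](C(c3ccccc3)c3ccccc3)C[C@H]2O)cn1` in this assay gives 44.1 nM.

Among the measured compounds shown here, of the two numbers in hand, compound 2 carries the higher one; the only neighbour, compound 1, sits at a lower number, and the gap between them lies beyond the scatter of the measurement. The two differ in more than one place, so what the gap shows is only the two values themselves, not the effect of any single change.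

Compound 3 `O[C@@H]1C[C@@H](C(c2ccccc2)c2ccccc2)OC[C@H]1NCc1ccc2occc2c1` is the unmeasured member. It departs from compound 2 in one place: 1-benzofuran-5-yl in place of 6-methoxypyridin-3-yl on a saturated chain carbon bound to an amine nitrogen. For the measured compounds named here, no pair of measured compounds covers this exchange, so there is no measured step to lean on. The change keeps an aromatic group on the same saturated chain carbon bound to the amine nitrogen and trades a ring with a methoxy group for a fused two-ring system. In that situation a step of the size a 1.3-fold lower number from compound 2 to compound 3 (0.10 log units; within the scatter) is expected, which amounts to no change beyond the scatter in either direction. Compound 3 is therefore estimated at 35 nM in this assay, with a plausible range from 12 nM to 100 nM.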

Compound 3, inhibition constant: 234 nM
Estimate against measurement, compound 3: 6.7-fold (0.83 log units) below; the whole stated range lies below it.
By their numbers in this assay, from the lowest: compound 1; then compound 2; then compound 3.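

Among the compounds shown here, this is the first step that can be read at this position: in this assay, 1-benzofuran-5-yl in place of 6-methoxypyridin-3-yl on a saturated chain carbon bound to an amine nitrogen gives a 5.3-fold higher number from compound 2 to compound 3 (0.72 log units; beyond the scatter) and the step lies beyond the scatter. The earlier pair differed in more than one place and could not isolate any single group, whereas here all else is held constant, and the exchange of one aromatic group for another at this place is clearly not neutral, with the fused two-ring system giving the weaker inhibitor of the two. Nothing among the data accounts for this step, so its origin remains unassigned.

From the compounds shown here alone, whether the same exchange would bring a step of similar size on the core of compound 1 remains open, as this single pair cannot show it. Also open, going by these compounds, is how other groups at this place, such as a plain phenyl or a 1-benzothiophen-5-yl, would compare with the two groups seen here.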